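Moving a Fluorine on the Benzyl Group and Cytotoxicity

The compounds below may be only part of what the source reports. "The series", "measured", "known", "first", "only" and "open" are said of these compounds alone.

Measured compounds:
compound 1 `Cn1cc(SCc2nnc(S)n2-c2c(Cl)cccc2Cl)c2ccccc21`: > 100000 nM
compound 2 `Cn1cc(SCc2nnc(SCc3ccc(Cl)cc3F)n2-c2c(Cl)cccc2Cl)c2ccccc21`: 87300 nM

Compound 1 reaches only a limit of this assay, (the limit of > 100000 nM in this assay, at which 1 of the 2 values shown sits). In a toxicity assay on HEK-293T cells (Homo sapiens) for cytotoxicity, read by CCK-8 assay, with a stated time of 48 h (a higher number here means that more compound is tolerated, a lower number that less compound is tolerated), compound 2 gives 87300 nM, the only number shown among the two values. Among the measured compounds shown here, the one measured step, an at least 1.1-fold lower number from compound 1 to compound 2 (0.05 log units; that floor lies within the scatter), has a floor that lies within the scatter, so it does not show a real change.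

Compound 3 `Cn1cc(SCc2nnc(SCc3ccc(Cl)c(F)c3)n2-c2c(Cl)cccc2Cl)c2ccccc21` differs from compound 2 by 4-chloro-3-fluorophenyl in place of 4-chloro-2-fluorophenyl on a saturated chain carbon bound to a sulfur. No measured step moves a fluorine within a ring that already carries it; the only step shown adds the whole benzyl group onto a sulfur, a different kind of change, and even that stays within the scatter. The expected step is therefore a 1.0-fold lower number from compound 2 to compound 3 (0.01 log units; within the scatter), that is, no change beyond the usual scatter. Compound 3 is estimated at 85000 nM, in the range 45000 nM to 160000 nM.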

Compound 3, half-maximal cytotoxic concentration: > 100000 nM
Compound 3 was reported as a limit (the forecaster's own chance of this, stated with the estimate: 30%); middle value at least 1.1-fold (0.07 log units) away from the limit.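

In this assay compound 3 gives > 100000 nM, which is a limit of the assay and not a number. Among the compounds shown here, this is the first look at moving the fluorine within the ring: 4-chloro-3-fluorobenzyl in place of 4-chloro-2-fluorobenzyl gives an at least 1.1-fold higher number from compound 2 to compound 3 (0.05 log units; that floor lies within the scatter), so the move shows no real change in how much compound the cells tolerate. The step between compound 1 and compound 3 cannot be read, and the two compounds rest at one and the same limit: the limit of > 100000 nM in this assay, at which 2 of the 3 values shown sit.

On these data alone, what stays open is whether a benzyl group without fluorine, or one carrying a carboxylic acid or an amine in place of the chlorine, would give a real change in this assay. A longer chain between the sulfur and the ring is open in the same way.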